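The source may report more compounds than this note shows. Statements on the series, on what has been measured and on what is new or still open speak of the compounds shown alone.

Measured so far:
Compound 1 `CC(=O)N1CCN(c2nc3c(c(-c4ccccc4C)n2)C(=O)N(Cc2cc(C(F)(F)F)cc(C(F)(F)F)c2)C[C@@H](C)CO3)CC1` gives 0.345 nM in a functional assay on ileum for antagonist activity at Substance-P receptor (Cavia porcellus); a lower number here means a stronger inhibitor, a higher number a weaker inhibitor.
Compound 2 `Cc1ccccc1-c1nc(N(C)C)nc2c1C(=O)N(Cc1cc(C(F)(F)F)cc(C(F)(F)F)c1)CCCO2` gives 0.679 nM in this assay.

Compound 2 carries the higher of the two numbers, but the value of compound 1 lies within the scatter of it, so the two cannot be ranked against each other. Compound 3 `CC(=O)N1CCN(c2nc3c(c(-c4ccccc4C)n2)C(=O)N(Cc2cc(C(F)(F)F)cc(C(F)(F)F)c2)CCCO3)CC1` has not yet been measured in this assay. It differs from compound 2 in one place: 4-acetylpiperazin-1-yl in place of dimethylamino on an aromatic carbon. The same 4-acetylpiperazin-1-yl group is present in compound 1, which lies within the scatter of compound 2. Without a measured pair showing this change, a step of a 1.5-fold lower number from compound 2 to compound 3 (0.18 log units; within the scatter) is expected, no larger than the scatter. Compound 3 is estimated at 0.45 nM, within 0.18 nM to 1.2 nM.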

Compound 3, antagonist equilibrium constant: 0.105 nM
Compound 3: the middle estimate sits 4.3-fold (0.63 log units) above what was measured, and the stated range ends above it.
By their numbers in this assay, from the lowest: compound 3; then compounds 1 and 2 (each within the scatter of the next).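

Swapping dimethylamino for 4-acetylpiperazin-1-yl on the aromatic carbon between two ring nitrogen atoms gives a 6.5-fold lower number from compound 2 to compound 3 (0.81 log units; beyond the scatter) in this assay and shows that this position responds to the change beyond the scatter. Hydrogen in place of methyl on a saturated ring carbon gives a 3.3-fold lower number from compound 1 to compound 3 (0.52 log units; beyond the scatter) and shows that this ring carbon also affects the number when 4-acetylpiperazin-1-yl is present. Nothing available explains either step. As far as these compounds go, it remains open whether morpholine or an unacylated piperazine at the aromatic carbon would give a similar step. From the compounds shown here alone, an ethyl group on the saturated ring carbon is equally open.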